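This account rests on a few compounds, and the source may have more. Where it says the series, first, only, none or still open, it means among the compounds named here.

In a functional assay on Vero cells (Chlorocebus sabaeus) for inhibition (a lower number here means a stronger inhibitor, a higher number a weaker inhibitor), compound 1 `COc1cccc(Cn2cnc3c(-c4ccco4)ncnc32)c1` reads > 625 ug/mL, which is a limit of the assay and not a number. Going by the values given here, compound 2 `Fc1ccc(Cn2cnc3c(-c4ccco4)nc(Cl)nc32)cc1` gives 11.5 ug/mL, the only true number so far. Compound 3 `COc1cccc(Cn2cnc3c(-c4ccco4)nc(Cl)nc32)c1` carries 3-methoxyphenyl in place of 4-fluorophenyl on a saturated chain carbon bound to an aromatic nitrogen. Among the compounds with values here, compound 1 shares that group but differs from compound 3 elsewhere, and no measured step isolates this exchange. The expected change is no larger than the scatter, an estimated 1.3-fold higher number from compound 2 to compound 3 (0.12 log units; within the scatter). For compound 3 the estimated value is 15 ug/mL, with an expected range from 4 ug/mL to 60 ug/mL.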

Compound 3, half-maximal inhibitory concentration: > 10 ug/mL
Compound 3: no number, only a limit; the forecaster's own chance of this, stated with the estimate: 15%; the middle value is on the limit's open side.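

Going by these compounds alone, the result for compound 3 in this assay is a limit and not a number, so no step to it from compound 2 or compound 1 can be read. The compounds shown leave open what either 3-methoxyphenyl in place of 4-fluorophenyl or chloro in place of hydrogen does to the inhibition.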